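Thiazolyl acetamides on fluoroquinolinone and phenylquinolinone cores

The source may report more compounds than this note shows. Statements on the series, on what has been measured and on what is new or still open speak of the compounds shown alone.

Three compounds carry a measurement. Compound 1 `O=C(CN1CCN(c2cc(=O)[nH]c3ccc(F)cc23)CC1)Nc1nc(-c2ccccc2)cs1` and compound 2 `COc1ccc(-c2csc(NC(=O)CN3CCN(c4cc(=O)[nH]c5ccc(F)cc45)CC3)n2)cc1` share one core; compound 3 `COc1ccc(-c2csc(NC(=O)CN3CCN(c4cc(=O)n(-c5ccccc5)c5ccccc45)CC3)n2)cc1` sits on another core. The difference between the two cores is not broken down here. In a functional assay on T47D cells (Homo sapiens) for cytotoxicity, read by MTT assay, with a stated time of 3 h (a higher number here means a weaker inhibitor, a lower number a stronger inhibitor), compound 1 gives 7200 nM, compound 2 gives 16900 nM and compound 3 gives 8110 nM. For the measured compounds named here, the one step counted so far, (hydrogen in place of methoxy on an aromatic carbon), gave a 2.3-fold lower number from compound 2 to compound 1 (0.37 log units; beyond the scatter), so taking the methoxy off the phenyl ring lowered the number beyond the usual scatter on that core. Compound 3 and compound 1 lie within the scatter of each other, while compound 3 and compound 2 differ beyond it, though no single change connects them.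

Compound 4 `O=C(CN1CCN(c2cc(=O)n(-c3ccccc3)c3ccccc23)CC1)Nc1nc(-c2ccccc2)cs1` is not yet measured. Going by the values given here, it differs from compound 3 by hydrogen in place of methoxy on an aromatic carbon, the same change as the one from compound 2 to compound 1, at a place described in the same words. Among the compounds with values here, with only one prior instance, on a different core, the expectation for compound 4 is the estimate a 2.1-fold lower number from compound 3 to compound 4 (0.33 log units; beyond the scatter), a step of about the size seen before, slightly widened for the change of core. Resting on a 2.3-fold lower number from compound 2 to compound 1 (0.37 log units; beyond the scatter), compound 4 is expected in this assay to give 3800 nM, with a likely range from 1500 nM to 9500 nM.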

Compound 4, half-maximal inhibitory concentration: 10300 nM
Beside the measured number, compound 4's estimate is 2.7-fold (0.43 log units) below it; measured number above the stated range.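

In this assay, the change from 4-methoxyphenyl to phenyl on the core of compound 3 gives a 1.3-fold higher number from compound 3 to compound 4 (0.10 log units; within the scatter), so on this core the step cannot be told apart from repeated-measurement noise, unlike the step on the core of compound 1. The change therefore does not carry over as a fixed step between these two cores, and the result on one core is a poor guide to the result on the other: the same change on two cores in this assay, a 2.3-fold lower number (0.37 log units; beyond the scatter) from compound 2 to compound 1 and a 1.3-fold higher number (0.10 log units; within the scatter) from compound 3 to compound 4, 3.0-fold (0.47 log units) apart, beyond the scatter of two such steps

This rests on one matched pair per core, so it shows that the two steps differ but does not show what in the cores sets them apart, nor whether the gap would recur with any other pair in the series.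

The two cores differ in more than one place, and the compounds shown do not separate those differences, so it remains open which of them goes with the change in behaviour of the step. Also open, from the compounds shown here alone, is whether an amine, a carboxylic acid or a longer alkoxy chain at the same place on the phenyl ring would follow the pattern of one core, of both or of neither.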